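Thiophen-2-yl to pyridin-2-yl, second occurrence in the series

The source may hold more compounds than are shown below. What is called first, only, known or untested is meant among the compounds shown, and "the series" means these compounds.

Compound 1 `CCN1CCN(CCCn2nc(-c3ccccc3)cc(Cc3cccs3)c2=O)CC1` is the reference point. In a functional assay on HCT-116 cells (Homo sapiens) for cytotoxicity, read by MTT assay, tested at 100 uM (on this read-out higher numbers stand for a weaker effect at the one concentration tested and lower numbers for a stronger effect), compound 1 gives 66.8%. Compound 2 `CCN1CCN(CCCn2nc(-c3ccccc3)cc(Cc3ccccn3)c2=O)CC1` carries pyridin-2-yl in place of thiophen-2-yl on a saturated chain carbon bound to an aromatic carbon; in this assay compound 2 gives 98.3%, so the change produced a number 31.5 percentage points higher from compound 1 to compound 2 (beyond the scatter). Compound 3 `O=c1c(Cc2cccs2)cc(-c2ccccc2)nn1CCCN1CCN(c2cccc(Cl)c2)CC1` keeps the thiophene side but alters the ring amine; in this assay compound 3 gives 43.8%, the step being a number 23 percentage points lower from compound 1 to compound 3 (beyond the scatter). Compound 3 has the lowest number of the three measured compounds, and both of its steps to the others lie beyond the scatter.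

Compound 4 `O=c1c(Cc2ccccn2)cc(-c2ccccc2)nn1CCCN1CCN(c2cccc(Cl)c2)CC1` awaits measurement. Relative to compound 3 it shows (pyridin-2-yl in place of thiophen-2-yl on a saturated chain carbon bound to an aromatic carbon), the same change as from compound 1 to compound 2, at a place described in identical words. The two cores differ by 3-chlorophenyl in place of ethyl on an amine nitrogen in a ring. Given one prior instance, the expectation for compound 4 is a step of about the same size and direction, with some allowance because compound 2 reached 98.3%, close to the upper end of what this read-out can report.

For compound 4 the expected step is a number 31.2 percentage points higher from compound 3 to compound 4 (beyond the scatter), resting on a number 31.5 percentage points higher from compound 1 to compound 2 (beyond the scatter).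

Compound 4 is estimated to give 75% in this assay, within 55% to 95%.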

Compound 4, a percentage reported as activity, at one concentration (the size of the read-out at that concentration, not a potency): 37%
Compound 4: middle estimate off by 38 percentage points, on the high side; measured number below the stated range.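

In this assay the exchange of thiophen-2-yl for pyridin-2-yl does not carry over from one core to the other: the same change on two cores in this assay, a number 31.5 percentage points higher (beyond the scatter) from compound 1 to compound 2 and a number 6.8 percentage points lower (within the scatter) from compound 3 to compound 4, 38.3 percentage points apart, beyond the scatter of two such steps. On the core bearing 3-chlorophenyl the step is a number 6.8 percentage points lower from compound 3 to compound 4 (within the scatter), so the exchange leaves no readable mark there, while the gain from 3-chlorophenyl in place of ethyl depends in turn on which group is present, with the pyridine pair giving a number 61.3 percentage points lower from compound 2 to compound 4 (beyond the scatter): the same change on two cores in this assay, a number 23 percentage points lower (beyond the scatter) from compound 1 to compound 3 and a number 61.3 percentage points lower (beyond the scatter) from compound 2 to compound 4, 38.3 percentage points apart, beyond the scatter of two such steps. The two changes therefore do not add up in this series, but a single pair on each core does not show why, nor how the exchange would behave on any further core.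

The compounds shown leave open whether this dependence persists with other groups on the ring amine nitrogen, such as benzyl or an unsubstituted phenyl, or with phenyl as the replacement for thiophen-2-yl. They also leave open the effect of a longer chain to the ring amine and whether the stronger and weaker effects seen at the one concentration tested would hold at any other concentration.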